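This account rests on a few compounds, and the source may have more. Where it says the series, first, only, none or still open, it means among the compounds named here.

Measured so far:
- Compound 1, `O=C(Nc1ccc(C(=O)O)cc1)Nc1ccc(F)c(C(F)(F)F)c1`, gives < 7 uL/min
- Compound 2, `O=C(Nc1ccc(F)c(C(F)(F)F)c1)Nc1cnccn1`, gives 160 uL/min
- Compound 3, `NC(=O)c1ccccc1NC(=O)Nc1ccc(F)c(C(F)(F)F)c1`, gives 69 uL/min

All three ureas share one core and were run in an ADME assay on microsomes from liver (Mus musculus) for metabolic stability, using NADPH, with a stated time of 60 min; on this read-out higher numbers stand for fast clearance and lower numbers for slow clearance. Among the two values that are numbers, compound 2 with 160 uL/min stands highest; compound 3 with 69 uL/min sits lower, and the gap between the two is beyond the usual scatter of this assay. Compound 1 stands apart, as its result is a limit of the assay and not a number, namely (the limit of < 7 uL/min in this assay, at which 1 of the 3 values shown sits).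

The unmeasured compound 4, `O=C(Nc1cccnc1)Nc1ccc(F)c(C(F)(F)F)c1`, differs from compound 2 in one place: pyridin-3-yl in place of pyrazin-2-yl on an amide-type nitrogen. Going by the values given here, no step between two measured compounds of this kind is available, so the expectation rests on the value of compound 2 alone, which is 160 uL/min, and on the small size of the change. Compound 4 is therefore expected to stay in the same region as compound 2. The expected step is a 1.3-fold lower number from compound 2 to compound 4 (0.12 log units; within the scatter), a move that lies within the usual scatter rather than beyond it. Compound 4 is estimated at 120 uL/min, with a range from 50 uL/min to 280 uL/min.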

Compound 4, intrinsic clearance in a liver preparation (reported as CLH), per the amount of preparation that the assay uses: 154 uL/min
Estimate against measurement, compound 4: 1.3-fold (0.11 log units) below, and the stated range covers the measured number.
By their numbers in this assay, from the lowest: compound 3; then compounds 4 and 2 (each within the scatter of the next). At a limit, below all of these: compound 1.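

Setting pyridin-3-yl in place of pyrazin-2-yl on an amide-type nitrogen gives, in this assay, a 1.0-fold lower number from compound 2 to compound 4 (0.02 log units; within the scatter), and this is the only step shown here that can be read between two compounds differing in one place. It shows that, at this position, a six-membered aromatic ring with 1 hetero atom and one with 2 hetero atoms cannot be told apart on this read-out, so the hetero atom that leaves and the hydrogen-bond acceptor count that goes with it make no difference beyond the scatter for this pair. Nothing shown gives a reason for this outcome, and the one limit on record does not bear on this pair.

One pair at one position cannot say whether the same holds for other aromatic rings, or how far this read-out can move when the group on this nitrogen is altered more strongly. Going by these compounds, whether an amine or a longer chain in place of pyridin-3-yl would separate from compound 4 in this assay remains open, as does the effect of any change elsewhere on the shared core.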